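Compound 2 to compound 4: a dihydroxyphenyl swap

The source may hold more compounds than are shown below. What is called first, only, known or untested is meant among the compounds shown, and "the series" means these compounds.

In a functional assay on HeLa cells (Homo sapiens) for inhibition, read by MTT assay, with a stated time of 72 h (a lower number here means a stronger inhibitor, a higher number a weaker inhibitor), compound 1 (`COc1ccc(C(=O)/C=C/c2cc(OC)c(OC)cc2OC)cc1`) gives 37600 nM. Compound 2 (`COc1cc(OC)c(OC)cc1/C=C/C(=O)c1ccc(O)cc1O`) gives 37600 nM and so stands level with compound 1. Compound 3 (`COc1cc(C(=O)/C=C/c2cc(OC)c(OC)cc2OC)ccc1O`) gives > 150000 nM, which is a limit and not a number.

The next compound for this assay is compound 4 (`COc1cc(OC)c(OC)cc1/C=C/C(=O)c1cc(O)ccc1O`), still unmeasured. The change is 2,5-dihydroxyphenyl in place of 2,4-dihydroxyphenyl on a carbonyl carbon, with 2,5-dihydroxyphenyl in place of 2,4-dihydroxyphenyl on a carbonyl carbon. Going by the values given here, the one measured step that bears on it is no change at the digits printed from compound 1 to compound 2 (within the scatter), which shows no size beyond the scatter. On that basis no shift in either direction is expected in this assay. The expected step is a 1.1-fold lower number from compound 2 to compound 4 (0.03 log units; within the scatter), which stays within the scatter. With compound 3 at > 150000 nM, a limit, the upper end of the range is left wide. For compound 4 the estimate is 35000 nM, with an expected range of 12000 nM to 110000 nM.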

Compound 4, half-maximal inhibitory concentration: > 150000 nM
Compound 4 ended at the assay's limit (the forecaster's own chance of this, stated with the estimate: 15%); middle value at least 4.2-fold (0.63 log units) away from the limit.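

In this assay, the group on the carbonyl carbon matters even when its atoms stay the same: 2,5-dihydroxyphenyl in place of 2,4-dihydroxyphenyl gives an at least 3.9-fold higher number from compound 2 to compound 4 (0.60 log units; beyond the scatter), whereas the earlier swap gave no change at the digits printed from compound 1 to compound 2 (within the scatter). Replacing 4-methoxyphenyl with 2,5-dihydroxyphenyl gives an at least 3.9-fold higher number from compound 1 to compound 4 (0.60 log units; beyond the scatter), so the dihydroxyphenyl group tolerated in compound 2 does not carry over to its isomer in compound 4. Compound 4 reads > 150000 nM, which is a limit, so both new steps give only a minimum size: the limit of > 150000 nM in this assay, at which 2 of the 4 values shown sit.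

As far as these compounds go, how far compound 4 lies past that limit remains open. Also open, from the compounds shown here alone, is whether an amine or a carboxylic acid on the ring at this carbonyl carbon would read level with compound 2 or reach the limit.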